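This account rests on a few compounds, and the source may have more. Where it says the series, first, only, none or still open, it means among the compounds named here.

In a functional assay on ECa-109 cells (Homo sapiens) for antiproliferative activity, read by MTT assay, with a stated time of 48 h (on this read-out higher numbers stand for weaker inhibition and lower numbers for stronger inhibition), compound 3, with the structure `Cn1cc(C2=C(c3nn(CCCO)c4ncccc34)C(=O)NC2=O)c2ccccc21`, is known only as a limit. In this assay compound 3 gives > 100000 nM, which is the limit of the assay rather than a measured number. Compound 1, `Cn1cc(C2=C(c3nn(CCn4ccnc4)c4ncccc34)C(=O)NC2=O)c2ccccc21`, sits at the same kind of limit. In this assay compound 1 gives > 100000 nM, again a limit and not a number. Compound 2, `CN1CCN(CCCn2nc(C3=C(c4cn(C)c5ccccc45)C(=O)NC3=O)c3cccnc32)CC1`, likewise reaches only a limit. In this assay compound 2 gives > 100000 nM, which is a limit as well. Because all three values sit at the limit of > 100000 nM in this assay, at which 3 of the 3 values shown sit, the steps between them cannot be read: the step that the two limits leave unreadable from compound 1 to compound 2, the step that the two limits leave unreadable from compound 1 to compound 3 and the step that the two limits leave unreadable from compound 2 to compound 3 are each left without a size by the two limits on either side. Compound 4, `Cn1cc(C2=C(c3nn(CCCN4CCCCC4)c4ncccc34)C(=O)NC2=O)c2ccccc21`, differs from compound 3 in one place: piperidin-1-yl in place of hydroxy on a saturated chain carbon, three bonds along the chain from an aromatic nitrogen. The measured steps that touch this same chain position are exactly those unreadable ones, so they give neither a direction nor a size to expect. All three known values rest at the limit of > 100000 nM in this assay, at which 3 of the 3 values shown sit, and the expected step that the limit leaves unreadable from compound 3 to compound 4 is therefore one that leaves compound 4 at that limit too. Compound 4 is accordingly estimated at 150000 nM, with a range from 30000 nM to 600000 nM, and with a good chance that only a limit is reported once more.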

Compound 4, half-maximal inhibitory concentration: 42300 nM
The estimate for compound 4 lay 3.5-fold (0.55 log units) above the measured number; the range from low to high includes it.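

In this assay, among the compounds shown here, compound 4 is the first compound here to give a number and not a limit, so a change on this saturated chain carbon, three bonds along the chain from an aromatic nitrogen, can move the read-out, and placing piperidin-1-yl in place of hydroxy gives an at least 2.3-fold lower number from compound 3 to compound 4 (0.37 log units; beyond the scatter) on this scale, where lower means stronger inhibition. The other two side chains also fall behind piperidin-1-yl, with an at least 2.3-fold lower number from compound 2 to compound 4 (0.37 log units; beyond the scatter) when it replaces 4-methylpiperazin-1-yl and an at least 2.3-fold lower number from compound 1 to compound 4 (0.37 log units; beyond the scatter) when (piperidin-1-yl)methyl replaces 1H-imidazol-1-yl, so a ring on the chain is not enough by itself, as compound 1 and compound 2 also carry one. For the compounds shown here, these three sizes are minimum sizes, the steps among the earlier compounds still cannot be read, and compound 4 alone stands clear of the shared limit: the limit of > 100000 nM in this assay, at which 3 of the 4 values shown sit.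

As far as these compounds go, it remains open whether a longer chain, a morpholin-4-yl ring or a plain dimethylamino group would move the number further from compound 4 and its 42300 nM. From the compounds shown here alone, how far compound 3 truly lies from compound 4 is also open, since compound 3 is known only as a limit.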